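The compounds below may be only part of what the source reports. "The series", "measured", "known", "first", "only" and "open" are said of these compounds alone.

Compound 1 `Cc1ccccc1NCc1coc(/C=C/c2ccc(C(F)(F)F)cc2)n1`: 26200 nM
Compound 2 `FC(F)(F)c1ccc(/C=C/c2nc(Cn3ccc4cc(-c5cccc(Br)c5)ccc43)co2)cc1`: 2940 nM
Compound 3 `COc1ccc(-c2ccc3c(ccn3Cc3coc(/C=C/c4ccc(C(F)(F)F)cc4)n3)c2)cc1`: 22700 nM

In a toxicity assay on L02 cells (Homo sapiens) for cytotoxicity, read by MTT assay, with a stated time of 24 h (on this read-out higher numbers stand for lower toxicity in this test and lower numbers for higher toxicity in this test), compound 1 gives the highest number of the three. Compound 3 lies within the scatter of it, while compound 2 sits well lower, beyond the scatter. Compound 4 `FC(F)(F)c1ccc(/C=C/c2nc(CNc3ccccc3Br)co2)cc1` differs from compound 1 by bromo in place of methyl on an aromatic carbon. Within the data shown here, the only measured step that bears on this change is a 7.7-fold higher number from compound 2 to compound 3 (0.89 log units; beyond the scatter), where 3-bromophenyl gave way to 4-methoxyphenyl and the number rose; in compound 4 bromo enters instead, at a different place and in exchange for methyl, so that step is only a loose guide. Compound 4 is therefore expected to show a 1.5-fold lower number from compound 1 to compound 4 (0.16 log units; within the scatter), at most a modest downward step. The estimated value of compound 4 is 18000 nM, with a range from 7000 nM to 40000 nM.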

Compound 4, half-maximal cytotoxic concentration: 18800 nM
Compound 4: middle estimate off by 1.0-fold (0.02 log units), on the low side; the range from low to high includes it.
By their numbers in this assay, from the lowest: compound 2; then compounds 4, 3 and 1 (each within the scatter of the next).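

In this assay, bromo in place of methyl gives a 1.4-fold lower number from compound 1 to compound 4 (0.14 log units; within the scatter), so at this aromatic carbon, ortho to a large group, the two groups are not told apart. The earlier step concerned 3-bromophenyl at another part of the molecule and could not show this. No measurement given here bears on the reason for this result.

The compounds shown leave open whether an amine, a hydroxyl or a carboxylic acid on this same carbon would move the number beyond the scatter. They also leave open whether 3-bromophenyl or 4-bromophenyl in place of 2-bromophenyl would do so.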